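Swapping a Chlorophenyl for a Methoxy-Methylphenyl Group

A few compounds are considered here, and "the series" means these few. Any claim that something is new, unique, unknown or untested is made for them only; others in the source may bear on it.

Measured so far:
compound 1 `Cc1nc(N2CCN(C)CC2)c2nc(-c3ccccc3Cl)n(C3CC3)c2n1` – 31%
compound 2 `Cc1nc(N2CCN(C)CC2)c2nc(-c3cccc(Cl)c3)n(C3CCOCC3)c2n1` – 25%

In an ADME assay (liver) for metabolic stability, with Liver microsome (Homo sapiens) as the target, read by LC-MS, using microsomes, with a stated time of 30 min, tested at 4 uM (on this read-out lower numbers stand for a less stable compound and higher numbers for a more stable compound), compound 1 gives 31% and compound 2 gives 25%. Compound 2 stands lowest of the two numbers, but its nearest neighbour, compound 1, lies within the usual scatter, so no order between the two can be read. Compounds 1 and 2 differ from each other in more than one place, and only what their two values show can be said of them.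

Compound 3 `COc1ccc(-c2nc3c(N4CCN(C)CC4)nc(C)nc3n2C2CCOCC2)c(C)c1` has not yet been measured in this assay. It differs from compound 2 in one place: 4-methoxy-2-methylphenyl in place of 3-chlorophenyl on an aromatic carbon. For the measured compounds named here, with no measured step available to rest on, the step is expected to stay within the scatter, a number 3 percentage points lower from compound 2 to compound 3 (within the scatter). Compound 3 is estimated at 22%, with a range from 8% to 42%.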

Compound 3, percent of the compound remaining: 21%
Compound 3: the middle estimate sits 1 percentage points above what was measured; the range from low to high includes it.
By their numbers in this assay, from the lowest: compounds 3, 2 and 1 (each within the scatter of the next).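

For the compounds shown here, this is the first comparison in this assay that turns on a single place, the aromatic carbon between two ring nitrogen atoms, next to the ring atom that bears the oxan-4-yl group. There, 4-methoxy-2-methylphenyl in place of 3-chlorophenyl gives a number 4 percentage points lower from compound 2 to compound 3 (within the scatter), so exchanging the chlorine for two different substituents on the phenyl ring leaves the two compounds indistinguishable on this read-out. Nothing at hand accounts for this result.

From the compounds shown here alone, the step changes the methoxy, the methyl and the chlorine together, so what each contributes on its own stays open. Also open, going by these compounds, is whether a phenyl ring carrying an amine or a carboxylic acid at this position would give a step beyond the scatter.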